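The compounds below may be only part of what the source reports. "The series", "measured", "known", "first", "only" and "open" are said of these compounds alone.

Measured compounds:
- Compound 1 `C#CCNC(=O)c1csc(C#Cc2ccccc2)n1`: > 40000 nM
- Compound 2 `C#Cc1nc(C(=O)OCC)cs1`: 2670 nM
- Compound 3 `C#CCNC(=O)c1csc(C#C)n1`: 2100 nM

All three results come from a functional assay on NCI-H522 cells (Homo sapiens) for cytotoxicity, with a stated time of 3 days; a higher number here means a weaker inhibitor, a lower number a stronger inhibitor. The entry for compound 1 is a limit of the assay and not a number. Compound 3 has the lowest of the two true numbers, but the other step, a 1.3-fold lower number from compound 2 to compound 3 (0.10 log units; within the scatter), shows that it stands level with compound 2.

The next compound is compound 4 `C#CCNC(=O)c1csc(Br)n1`, which has bromo in place of ethynyl on an aromatic carbon. Among the compounds with values here, no measured step makes this exact swap, so the guidance is indirect. The closer guide is an at least 19-fold lower number from compound 1 to compound 3 (1.27 log units; beyond the scatter), where hydrogen takes the place of phenyl on a triple-bonded carbon. This large step falls on the same side of the core as the new change. In contrast, a 1.3-fold lower number from compound 2 to compound 3 (0.10 log units; within the scatter) involves propargylamino in place of ethoxy on a carbonyl carbon and leaves the ethynyl untouched, so it says little here.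

The incoming bromo is far smaller than the phenyl-bearing group of compound 1, so a moderate rise is more likely than a collapse to the limit. The expected change is a 2.9-fold higher number from compound 3 to compound 4 (0.46 log units; beyond the scatter). For compound 4 the estimated value is 6000 nM, with an expected range from 1800 nM to 25000 nM.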

Compound 4, half-maximal inhibitory concentration: > 40000 nM
Compound 4: only a limit was reported (the forecaster's own chance of this, stated with the estimate: 15%); middle value at least 6.6-fold (0.82 log units) from the limit.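

In this assay, the result shows that the ethynyl on this ring carbon cannot simply be exchanged, as bromo in its place gives an at least 19-fold higher number from compound 3 to compound 4 (1.27 log units; beyond the scatter). Compound 1 had shown only that adding a phenyl to the end of the triple bond goes with a loss of measurable effect, whereas compound 4 shows the same outcome when the triple bond is gone altogether, so among the compounds shown, only those with the plain ethynyl, compound 2 and compound 3, give true numbers. The entry for compound 4 is a limit of the assay and not a number, so this step gives only a minimum size and compound 4 cannot be ranked against compound 1: the limit of > 40000 nM in this assay, at which 2 of the 4 values shown sit.

The compounds shown leave open whether any other group on this carbon, such as a nitrile or a methyl, would give a true number, or whether the ethynyl is needed. They also leave open whether a methyl on the end of the triple bond, far shorter than the phenyl of compound 1, would stay close to compound 3.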